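The source may hold more compounds than are shown below. What is called first, only, known or untested is meant among the compounds shown, and "the series" means these compounds.

Two compounds of the series carry a measured value in an ADME assay on PC-3 cells (Homo sapiens) for cytotoxicity, read by WST assay, tested at 100 uM; a lower number here means less inhibition, a higher number more inhibition at the concentration tested (going by the name of the read-out). Compound 1 `O=C(Nc1cccc([N+](=O)[O-])c1)C1CCCN(C(=O)c2cc(C(F)(F)F)cc(C(F)(F)F)c2)C1` gives 9% in this assay, and compound 2 `COC(=O)c1cccc(NC(=O)C2CCCN(C(=O)c3cc(C(F)(F)F)cc(C(F)(F)F)c3)C2)c1` gives 0%. Among the measured compounds shown here, the only measured step so far is a number 9 percentage points lower from compound 1 to compound 2 (within the scatter). Of the two numbers, compound 2 holds the lower, but its gap to compound 1 is within the scatter, so the two compounds are not distinguishable on this read-out.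

Compound 3 `O=C(Nc1cccc(Oc2ccccc2)c1)C1CCCN(C(=O)c2cc(C(F)(F)F)cc(C(F)(F)F)c2)C1` differs from compound 2 by phenoxy in place of methoxycarbonyl on an aromatic carbon. For the measured compounds named here, the one measured step that bears on this change is the exchange between compound 1 and compound 2 at the same aromatic carbon, and it stayed within the scatter. Nothing measured points to a move beyond the scatter for the phenoxy analog either. Compound 3 is therefore expected to give about 6% in this assay, in the range 0% to 22%. The expected step of a number 6 percentage points higher from compound 2 to compound 3 (within the scatter) is accordingly none beyond the scatter.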

Compound 3, a percentage reported as inhibition, at one concentration (the size of the read-out at that concentration, not a potency): 1%
For compound 3 the middle estimate is 5 percentage points above the measured one; the range from low to high includes it.
By their numbers in this assay, from the lowest: compounds 2, 3 and 1 (each within the scatter of the next).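

In this assay the place on an aromatic carbon meta to a large group now carries phenoxy, which brings in a six-membered aromatic ring of carbon only, and the data show a number 1 percentage points higher from compound 2 to compound 3 (within the scatter) and a number 8 percentage points lower from compound 1 to compound 3 (within the scatter) on this read-out. Nitro and methoxycarbonyl alone could not show whether a group with its own ring would leave the number within the scatter; with phenoxy, 7 heavy atoms against the 4 of methoxycarbonyl, it does for this one exchange. Nothing at hand explains this result.

Going by these compounds, whether an amine or a carboxylic acid at this place would give a number beyond the scatter remains open. Also open, on these data alone, is what a change elsewhere on the shared core would do, since all three compounds keep it unchanged.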